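Shortening the Side Chain of Compound 2

A few compounds are considered here, and "the series" means these few. Any claim that something is new, unique, unknown or untested is made for them only; others in the source may bear on it.

Measured compounds:
Compound 1, `CCCCCCCCc1cn([C@H]2C[C@H](O)[C@@H](CO)O2)c(=O)[nH]c1=O`: in a functional assay on Raji cells (Homo sapiens) (on this read-out higher numbers stand for weaker inhibition and lower numbers for stronger inhibition), compound 1 gives 140 ug/mL.
Compound 2, `CCCCCCc1cn([C@H]2C[C@@H]3OP(=O)(O)OC[C@H]3O2)c(=O)[nH]c1=O`: in this assay compound 2 gives > 500 ug/mL, which is a limit of the assay and not a number.
Compound 3, `CCCCc1cn([C@H]2C[C@H](O)[C@@H](CO)O2)c(=O)[nH]c1=O`: in this assay compound 3 gives > 500 ug/mL, again a limit and not a number.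

Compound 2 therefore stands at the limit, with no number of its own; it shares that position with compound 3, as the limit of > 500 ug/mL in this assay, at which 2 of the 3 values shown sit, shows. The compound still to be measured is compound 4, `CCCCc1cn([C@H]2C[C@@H]3OP(=O)(O)OC[C@H]3O2)c(=O)[nH]c1=O`. It differs from compound 2 in one place: hydrogen in place of ethyl on a saturated chain carbon, four bonds along the chain from an aromatic carbon.

Within the data shown here, only one measured step speaks to this kind of change. It is an at least 3.5-fold higher number from compound 1 to compound 3 (0.55 log units; beyond the scatter), a shortening of the same chain at the same place, and it moved toward weaker inhibition by more than the scatter. The change from compound 2 to compound 4 is a shorter cut in the same direction, so no gain in inhibition is expected, and since compound 2 already sits at the limit, compound 4 is expected to remain there. Compound 4 is thus estimated at 800 ug/mL, within 500 ug/mL to 2000 ug/mL, which would mean a step that the limit leaves unreadable from compound 2 to compound 4.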

Compound 4, concentration for 50% inhibition: 165 ug/mL
Compound 4: the middle estimate sits 4.8-fold (0.69 log units) above what was measured, outside the stated range (below it).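

In this assay, hydrogen in place of ethyl on a saturated chain carbon, four bonds along the chain from an aromatic carbon, gives an at least 3.0-fold lower number from compound 2 to compound 4 (0.48 log units; beyond the scatter) and thus shows that, on the core shared by these two compounds, the shorter chain goes with stronger inhibition. The earlier step, an at least 3.5-fold higher number from compound 1 to compound 3 (0.55 log units; beyond the scatter) on a different core, is a cut at the same place that went toward weaker inhibition, so among the compounds shown, shortening this chain has no single direction. The true size of the new step stays unknown because compound 2 has only a limit and no number of its own: the limit of > 500 ug/mL in this assay, at which 2 of the 4 values shown sit.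

The two steps differ both in the core and in the length of chain removed, so these compounds cannot say which of the two differences reverses the direction. Also open, on these data alone, is how inhibition would change on the core of compound 4 with a longer chain, or with a chain that carries an amine or a carboxylic acid.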